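Difluorocyclobutyl for Methoxycyclobutyl on Two Cores

The source may hold more compounds than are shown below. What is called first, only, known or untested is meant among the compounds shown, and "the series" means these compounds.

Compound 1 `CCn1c(-c2cnc(C)nc2)nc2c(N[C@H]3CCN(C(=O)[C@H]4C[C@@H](OC)C4)C3)ncnc21` and compound 2 `CCn1c(-c2cnc(C)nc2)nc2c(N[C@H]3CCN(C(=O)C4CC(F)(F)C4)C3)ncnc21` share one core, while compound 3 `CCn1c(-c2cnc(C)nc2)nc2c(O[C@H]3CCN(C(=O)[C@H]4C[C@@H](OC)C4)C3)ncnc21` and compound 4 `CCn1c(-c2cnc(C)nc2)nc2c(O[C@H]3CCN(C(=O)C4CC(F)(F)C4)C3)ncnc21` share another; how the two cores differ is not broken down here. In a physicochemical assay for lipophilicity, read by HPLC (a higher number here means a more lipophilic compound, a lower number a more polar compound), compound 1 gives 0.9 and compound 2 gives 1.5. The change 3,3-difluorocyclobutyl in place of 3-methoxycyclobutyl on a carbonyl carbon thus produced a number 0.60 log units higher from compound 1 to compound 2 (beyond the scatter). In this assay compound 3 gives 1, which lies within the scatter of compound 1. The change 3,3-difluorocyclobutyl in place of 3-methoxycyclobutyl on a carbonyl carbon is the same change, made at the same place, on the core of compound 3. For compound 4 the expected value in this assay is 1.6, estimated to lie between 1.3 and 1.9. This estimate means a step of a number 0.60 log units higher from compound 3 to compound 4 (beyond the scatter), expected because a number 0.60 log units higher from compound 1 to compound 2 (beyond the scatter) was seen at the same place.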

Compound 4, distribution coefficient: 1.5
Beside the measured number, compound 4's estimate is 0.10 log units above it; low and high end bracket the measured number.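

In this assay, replacing 3-methoxycyclobutyl with 3,3-difluorocyclobutyl on the carbonyl carbon gave a number 0.50 log units higher from compound 3 to compound 4 (beyond the scatter) and in the same direction a number 0.60 log units higher from compound 1 to compound 2 (beyond the scatter) on the other core, so the change carried over between these two cores. This rests on one pair per core: it shows that the step repeated here, but not that it would hold on any further core in the series. Nothing available accounts for the repeat.

The compounds shown leave open what an amine, a carboxylic acid or a longer alkyl chain would give in place of either cyclobutyl group on this carbonyl carbon. They also leave open whether other groups would carry over between the two cores in the same way.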